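The source may hold more compounds than are shown below. What is called first, only, known or untested is meant among the compounds shown, and "the series" means these compounds.

Compound 1, whose structure is `COC(=O)/C=C/c1cccc(N(Cc2ccc(/C=C/c3cccc(Cl)c3)cc2)C(=O)C2CCCCC2)c1`, is the starting point here. For the measured compounds named here, in an assay on isolated protein with Bile acid receptor (Homo sapiens) as the target (on this read-out higher numbers stand for an effect only at larger amounts of compound and lower numbers for an effect already at smaller amounts), compound 1 gives 166 nM, the highest of the three numbers measured so far. Compound 2, `COC(=O)/C=C/c1cccc(N(Cc2ccc(/C=C/c3cccc(Cl)c3)cc2)C(=O)C(C)C)c1`, gives 162 nM; the change a 1.0-fold lower number from compound 1 to compound 2 (0.01 log units; within the scatter) is a step of the kind that repeated testing itself produces, so the two compounds cannot be told apart. Compound 3, `COC(=O)/C=C/c1cccc(N(Cc2ccc(/C=C/c3ccccc3)cc2)C(=O)C(C)C)c1`, gives 64.6 nM, and the step of a 2.5-fold lower number from compound 2 to compound 3 (0.40 log units; beyond the scatter) is a modest move to a lower number.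

Compound 4, `COC(=O)/C=C/c1cccc(N(Cc2ccc(-c3cc(Cl)ccc3OC)cc2)C(=O)C2CCCCC2)c1`, differs from compound 1 in one place: 5-chloro-2-methoxyphenyl in place of 2-(3-chlorophenyl)ethenyl on an aromatic carbon. Going by the values given here, neither measured step tests this kind of exchange; the nearest precedent is the step from compound 2 to compound 3, which only removed the chloro from the group that now leaves entirely. With no direct guide, a somewhat higher number is expected for compound 4 in this assay, a step of a 2.4-fold higher number from compound 1 to compound 4 (0.38 log units; beyond the scatter) with wide uncertainty. The estimate for compound 4 is 400 nM, in a range from 120 nM to 1500 nM.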

Compound 4, half-maximal effective concentration: 234 nM
Compound 4: middle estimate off by 1.7-fold (0.23 log units), on the high side, and the stated range covers the measured number.
By their numbers in this assay, from the lowest: compound 3; then compounds 2, 1 and 4 (each within the scatter of the next).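

In this assay, exchanging the group on this aromatic carbon, para to a large group, gives a step (a 1.4-fold higher number from compound 1 to compound 4 (0.15 log units; within the scatter)) that leaves compound 1 and compound 4 indistinguishable. The earlier compounds shown here changed only the chloro on this group, whereas here the whole 2-(3-chlorophenyl)ethenyl group gives way to 5-chloro-2-methoxyphenyl. The double bond outside aromatic rings leaves and a hydrogen-bond acceptor enters, yet the two numbers stay within the scatter of each other, and no measurement at hand explains this.

As far as these compounds go, whether removing the chloro from the new group would lower the number, as it did from compound 2 to compound 3, remains open. So does the effect of a hydroxy group in place of the methoxy, or a carboxylic acid in place of the methyl ester.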